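A few compounds are considered here, and "the series" means these few. Any claim that something is new, unique, unknown or untested is made for them only; others in the source may bear on it.

The compounds measured so far in an ADME assay on 184B5 cells (Homo sapiens) for cytotoxicity, read by sulforhodamine B assay, with a stated time of 48 h; on this read-out lower numbers stand for stronger inhibition of growth and higher numbers for weaker inhibition of growth:

Compound 1 `O=C1C(=O)N(CN(c2ccccc2)c2ccccc2)c2cccc(Cl)c21`: 96800 nM
Compound 2 `Cc1ccc2nc(/N=C3\C(=O)N(CN(c4ccccc4)c4ccccc4)c4cccc(Br)c43)sc2c1`: 70300 nM
Compound 3 `O=C1C(=O)N(CN(c2ccccc2)c2ccccc2)c2cccc(Br)c21`: 98500 nM

Compound 2 has the lowest of the three numbers, yet compound 1 and compound 3 both sit within the scatter of it. The step to compound 4 `Cc1ccc2nc(/N=C3\C(=O)N(CN(c4ccccc4)c4ccccc4)c4ccccc43)sc2c1` is hydrogen in place of bromo on an aromatic carbon. Among the measured compounds shown here, the only measured step that touches this ring, a 1.0-fold higher number from compound 1 to compound 3 (0.01 log units; within the scatter), exchanges one halogen for another rather than removing one, so it bears only loosely on the present change, but it shows that altering this substituent left the number unmoved. Compound 4 is therefore expected to show a 1.1-fold higher number from compound 2 to compound 4 (0.03 log units; within the scatter), with no step beyond the scatter in either direction. The estimate for compound 4 in this assay is 75000 nM, within a range of 35000 nM to 160000 nM.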

Compound 4, concentration for 50% growth inhibition: 27200 nM
Compound 4: middle estimate off by 2.8-fold (0.44 log units), on the high side; the measured number lies below the stated range.
By their numbers in this assay, from the lowest: compound 4; then compounds 2, 1 and 3 (each within the scatter of the next).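

In this assay, hydrogen in place of bromo on this aromatic carbon gives a 2.6-fold lower number from compound 2 to compound 4 (0.41 log units; beyond the scatter) and so takes the number beyond the scatter, whereas the earlier step of a 1.0-fold higher number from compound 1 to compound 3 (0.01 log units; within the scatter) stayed within it and kept a halogen on the ring. Having a halogen at this place therefore matters for compound 2 in a way that exchanging one halogen for another in a different pair could not reveal. Nothing available explains this step.

From the compounds shown here alone, it remains open whether a chloro, fluoro or methoxy group at this place would stand nearer to compound 2 or to compound 4. Also open, going by these compounds, is whether hydrogen in place of the halogen would move compound 1 or compound 3 in the same way.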